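The step from compound 3 to compound 4

This account rests on a few compounds, and the source may have more. Where it says the series, first, only, none or still open, it means among the compounds named here.

Compound 1 `COc1cccc(CNC(=O)c2nc3ccc(F)c(OCCc4ccccc4)c3c(=O)[nH]2)c1` gives > 20000 nM (a limit)
Compound 2 `COc1cccc(CNC(=O)c2nc3ccc(F)c(OCCc4ccc(N)cc4)c3c(=O)[nH]2)c1` gives > 20000 nM (a limit)
Compound 3 `Cc1cc(CNC(=O)c2nc3ccc(F)c(OCCc4ccc(C(=O)O)cc4)c3c(=O)[nH]2)ccc1F` gives > 20000 nM (a limit)

In an ADME assay on HEK293 cells (Homo sapiens) for cytotoxicity, read by resazurin assay, with a stated time of 72 h (a lower number here means that less compound is tolerated, a higher number that more compound is tolerated), compound 3 has no number, only a limit (> 20000 nM). It is not alone in this, and the whole set reads the same way, with the limit of > 20000 nM in this assay, at which 3 of the 3 values shown sit, as the one shared result.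

Compound 4 `O=C(O)c1ccc(CCOc2c(F)ccc3nc(C(=O)NCc4cccc(C5CC5)c4)[nH]c(=O)c23)cc1` differs from compound 3 in one group: 3-cyclopropylphenyl in place of 4-fluoro-3-methylphenyl on a saturated chain carbon bound to an amide-type nitrogen. Put simply, 3-cyclopropylphenyl stands in place of 4-fluoro-3-methylphenyl on a saturated chain carbon bound to an amide-type nitrogen.

Within the data shown here, the only measured step, a step that the two limits leave unreadable from compound 1 to compound 2, is a different change, amino in place of hydrogen on an aromatic carbon, so it gives no size to carry over. The expectation therefore rests on compound 3, whose limit is > 20000 nM. No step beyond the scatter is expected in this assay, in either direction. The estimated step is a step that the limit leaves unreadable from compound 3 to compound 4. For compound 4 the expected value is 25000 nM, quite possibly reported as a limit again (estimated range 12000 nM to 50000 nM).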

Compound 4, half-maximal cytotoxic concentration: > 20000 nM
Compound 4 ended at the assay's limit; the forecaster's own chance of this, stated with the estimate: 80%; the middle value is on the limit's open side.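

In this assay compound 4 gives > 20000 nM, which is a limit. Compound 3 also stands at a limit, so no step can be read between compound 3 and compound 4. The compounds shown leave open where the half-maximal cytotoxic concentration of any of them actually lies, and whether 3-cyclopropylphenyl in place of 4-fluoro-3-methylphenyl changes it at all.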